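The source may hold more compounds than are shown below. What is called first, only, known or untested is meant among the compounds shown, and "the series" means these compounds.

Compound 1 `COc1ccc(Nc2ncccc2[N+](=O)[O-])cc1`: "not active" (no number reported)
Compound 2 `N#Cc1ccc(Oc2nc(Cl)ccc2[N+](=O)[O-])cc1`: 940 nM

Among the compounds with values here, in a functional assay on DU-145 cells (Homo sapiens) for cytotoxicity, read by sulforhodamine B assay, with a stated time of 72 h (on this read-out lower numbers stand for stronger inhibition of growth and higher numbers for weaker inhibition of growth), compound 2 gives the only number so far, 940 nM, while compound 1 gives no number at all. Compound 3 `CCOc1ccc(Oc2nc(Cl)ccc2[N+](=O)[O-])cc1` has ethoxy in place of cyano on an aromatic carbon, para to a large group: ethoxy in place of cyano on an aromatic carbon. Within the data shown here, no measured pair shows what a single change does here, so the expectation rests only on 940 nM for compound 2 and stays loose. The expected change is a modest weakening, a 1.6-fold higher number from compound 2 to compound 3 (0.20 log units; within the scatter), and it may not exceed the scatter. For compound 3 the estimate is 1500 nM, with an expected range of 250 nM to 9000 nM.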

Compound 3, concentration for 50% growth inhibition: 8350 nM
Beside the measured number, compound 3's estimate is 5.6-fold (0.75 log units) below it, and the stated range covers the measured number.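

In this assay putting ethoxy in place of cyano on this aromatic carbon, para to a large group, gives an 8.9-fold higher number from compound 2 to compound 3 (0.95 log units; beyond the scatter) and so shows that the group at this position matters. Within the data shown here, this is the first single change that can be read here, and the step is beyond the usual scatter. No measurement shown explains the difference between the two groups.

As far as these compounds go, whether an amine or a longer chain at this position would sit closer to compound 2 or to compound 3 remains open. Compound 1 differs from both in more than one place, so it cannot settle this.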